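The source may hold more compounds than are shown below. What is called first, only, known or untested is meant among the compounds shown, and "the series" means these compounds.

In a functional assay on HepG2 cells (Homo sapiens) for cytotoxicity, read by spectrophotometry, with a stated time of 72 h (on this read-out lower numbers stand for stronger inhibition and higher numbers for weaker inhibition), compound 1 `COc1cc(-n2c(-c3ccc([N+](=O)[O-])cc3)cccc2=O)cc(OC)c1OC` reads < 10 nM, which is a limit of the assay and not a number. Going by the values given here, compound 2 `COc1cc(-c2cccc(=O)n2-c2ccc([N+](=O)[O-])cc2)cc(OC)c1OC` gives 941 nM, the only actual number so far. Compound 3 `COc1cc(-c2cccc(=O)n2-c2ccncc2)cc(OC)c1OC` is still unmeasured and differs from compound 2 as follows: pyridin-4-yl in place of 4-nitrophenyl on an aromatic nitrogen. The change places pyridin-4-yl in place of 4-nitrophenyl on an aromatic nitrogen. Among the compounds with values here, no measured step covers this exchange, so the call is tentative: in this assay a moderate step toward weaker inhibition is expected. The estimated value for compound 3 is 2500 nM, within an expected range of 600 nM to 10000 nM. The expected change is a 2.7-fold higher number from compound 2 to compound 3 (0.42 log units; beyond the scatter).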

Compound 3, half-maximal inhibitory concentration: 2520 nM
Beside the measured number, compound 3's estimate is 1.0-fold (0.00 log units) below it; the measured number falls inside the stated range.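

In this assay, the group on the aromatic nitrogen of the shared core affects the read-out: pyridin-4-yl in place of 4-nitrophenyl gives a 2.7-fold higher number from compound 2 to compound 3 (0.43 log units; beyond the scatter). Going by these compounds alone, this is the only readable step so far, and it covers a single exchange at a single position. Compound 1 enters no step and remains a limit of the assay, not a number: the limit of < 10 nM in this assay, at which 1 of the 3 values shown sits.

Still open, going by these compounds, is whether the shift follows the loss of the nitro group or the arrival of the ring nitrogen, as this exchange changes both at once. A plain phenyl or a 4-aminophenyl on the same nitrogen would separate the two.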